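The compounds below may be only part of what the source reports. "The series", "measured", "known", "first", "only" and "open" are said of these compounds alone.

The study reports three compounds in an ADME assay on cells for inhibition of cytochrome P450 11B1, mitochondrial (Homo sapiens), read by HTRF; on this read-out lower numbers stand for stronger inhibition and higher numbers for weaker inhibition. Compound 1 `O=C(Nc1cccnc1)c1ccc(Cl)cc1F` stands at a limit of that assay rather than at a number: in this assay compound 1 gives > 3000 nM. The two other compounds, built on a different core, return numbers: in this assay compound 2 `CS(=O)(=O)N[C@@H]1CCCc2c1cncc2N1CCc2cc(Cl)ccc2C1=O` gives 5150 nM, and compound 3 `CC(=O)N[C@@H]1CCCc2c1cncc2N1Cc2cc(Cl)ccc2C1=O` gives 2330 nM. Where compound 1 stands among these is therefore known only as a limit, and one of the three values shown rests at the limit of > 3000 nM in this assay, at which 1 of the 3 values shown sits.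

The account turns to compound 4 `O=C(Nc1cccnc1)c1ccc(Cl)cc1`, which has not yet been measured. It differs from compound 1 in one place: hydrogen in place of fluoro on an aromatic carbon. Going by the values given here, no step between two measured compounds mirrors this change, so no measured size of step guides the expectation. The chloro group and the group of 9 heavy atoms on that ring are untouched.

Compound 4 is expected to behave much like compound 1, so that the step that the limit leaves unreadable from compound 1 to compound 4 is expected to stay within the usual scatter. Compound 4 is estimated at 5000 nM in this assay, within a range from 2000 nM to 15000 nM, and the assay is quite likely to report only a limit again.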

Compound 4, half-maximal inhibitory concentration: > 3000 nM
Compound 4 ended at the assay's limit; the forecaster's own chance of this, stated with the estimate: 60%; the middle value lies beyond the limit too.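

In this assay compound 4 gives > 3000 nM, which is a limit and not a number. Compound 1 stands at that same limit, so no step can be read between compound 1 and compound 4: the limit of > 3000 nM in this assay, at which 2 of the 4 values shown sit.

The compounds shown leave open whether hydrogen in place of fluoro on that aromatic carbon changes the read-out in this assay at all.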